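The compounds below may be only part of what the source reports. "The series", "measured", "known", "first", "only" and "open" are said of these compounds alone.

Measured so far in a functional assay on CCRF-CEM cells (Homo sapiens) for inhibition, read by XTT assay, with a stated time of 72 h; a lower number here means a stronger inhibitor, a higher number a weaker inhibitor:
compound 1 `[N-]=[N+]=NCc1ncnc2c1ncn2[C@@H]1O[C@H](CO)[C@@H](O)[C@H]1O` gives 340 nM
compound 2 `OC[C@H]1O[C@@H](n2cnc3c(CSCc4ccccc4)ncnc32)[C@H](O)[C@@H]1O` gives 4650 nM
compound 3 `COCc1ncnc2c1ncn2[C@@H]1O[C@H](CO)[C@@H](O)[C@H]1O` gives 1140 nM

Compound 3 stands second highest of the three numbers in this assay. Its nearest neighbour is compound 1, with a 3.4-fold higher number from compound 1 to compound 3 (0.53 log units; beyond the scatter); its furthest is compound 2, with a 4.1-fold lower number from compound 2 to compound 3 (0.61 log units; beyond the scatter). Both steps are beyond the scatter, so compound 3 sits clearly between the two.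

Compound 4 `CSCc1ncnc2c1ncn2[C@@H]1O[C@H](CO)[C@@H](O)[C@H]1O` is not yet measured. The change from compound 3 is methylsulfanyl in place of methoxy on a saturated chain carbon bound to an aromatic carbon. Within the data shown here, two measured steps bear on it. Among the measured compounds shown here, the step of a 4.1-fold lower number from compound 2 to compound 3 (0.61 log units; beyond the scatter) is the only one that swaps a sulfur-bearing group for methoxy, but benzylsulfanyl also carries a benzyl that methylsulfanyl does not, so that step is only partly informative. The step of a 14-fold higher number from compound 1 to compound 2 (1.14 log units; beyond the scatter) again involves benzylsulfanyl and adds nothing separate. For the measured compounds named here, no measured pair exchanges methoxy for methylsulfanyl while keeping the same size; the groups match in heavy-atom count and acceptor count. A small step in this assay is therefore expected, if any, toward a higher number, likely near the edge of the scatter.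

Compound 4 is expected to give about 1600 nM, with a range from 600 nM to 4500 nM. This estimate means a step of a 1.4-fold higher number from compound 3 to compound 4 (0.15 log units; within the scatter), which is expected to stay close to the scatter.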

Compound 4, half-maximal inhibitory concentration: 3200 nM
Compound 4: middle estimate off by 2.0-fold (0.30 log units), on the low side, and the stated range covers the measured number.
By their numbers in this assay, from the lowest: compound 1; then compound 3; then compounds 4 and 2 (each within the scatter of the next).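

In this assay, the exchange of methoxy for methylsulfanyl keeps the heavy-atom and acceptor counts unchanged, yet the step (a 2.8-fold higher number from compound 3 to compound 4 (0.45 log units; beyond the scatter)) lies beyond the scatter, so at this saturated chain carbon the swap of oxygen for sulfur alone gives a readable difference, which the earlier benzylsulfanyl comparison could not separate from the added phenyl. With hydrogen in place of phenyl, the step (a 1.5-fold lower number from compound 2 to compound 4 (0.16 log units; within the scatter)) stays within the scatter, and the distance from the azido compound remains beyond it for methylsulfanyl (a 9.4-fold higher number from compound 1 to compound 4 (0.97 log units; beyond the scatter)), so the phenyl is not needed for most of the gap first seen with benzylsulfanyl. Nothing shown gives a measured reason for any of these steps.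

Still open, on these data alone, is whether an amine or a hydroxyl on this carbon, or a longer chain such as propylsulfanyl, would stay with the sulfur compounds or come closer to compound 1 at 340 nM in this assay. The compounds shown also leave open whether the difference between methoxy and methylsulfanyl would persist on any core other than the shared one.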